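Amino for ethyl on the benzamide of compound 2

The source may hold more compounds than are shown below. What is called first, only, known or untested is meant among the compounds shown, and "the series" means these compounds.

Measured so far:
compound 1, `CN(C)c1ccc(C(=O)Nc2cccc(NC(=O)COc3ccc4c(c3)NC(=O)CC4)c2)cc1` — > 10000 nM
compound 2, `CCc1ccc(C(=O)Nc2cccc(NC(=O)COc3ccc4c(=O)ccoc4c3)c2)cc1` — 235 nM

In an assay on isolated protein for inhibition of Rho-associated protein kinase 1 (Homo sapiens), read by scintillation counting, radiometric assay and 33P incorporation, with a stated time of 40 min, in the presence of a further agent that is not named here (a lower number here means a stronger inhibitor, a higher number a weaker inhibitor), compound 1 reports only a limit, > 10000 nM, and no number. Compound 2 gives the only number shown, 235 nM, and thus stands alone in this assay; no step between measured compounds is available for comparison.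

Compound 3, `Nc1ccc(C(=O)Nc2cccc(NC(=O)COc3ccc4c(=O)ccoc4c3)c2)cc1`, differs from compound 2 in one place: amino in place of ethyl on an aromatic carbon. Among the measured compounds shown here, with no measured step to lean on, the expected change in this assay is small, at most a modest weakening, and may lie within the scatter. Compound 3 is estimated at 500 nM, with a range of 100 nM to 3000 nM, so the expected step is a 2.1-fold higher number from compound 2 to compound 3 (0.33 log units; beyond the scatter).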

Compound 3, half-maximal inhibitory concentration: 802 nM
Compound 3: the middle estimate sits 1.6-fold (0.21 log units) below what was measured; the range from low to high includes it.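

In this assay, among the compounds shown here, going from 4-ethylphenyl to 4-aminophenyl gives a 3.4-fold higher number from compound 2 to compound 3 (0.53 log units; beyond the scatter), the first one-place step. This position therefore responds to the change, yet a measurable number remains with the amino group in place. Nothing in the data shown accounts for the size of this step. Still open, from the compounds shown here alone, is how a hydroxyl, a carboxylic acid or a longer chain would read in the same place. Also open, going by these compounds, is whether this step would carry over to a different core, such as that of compound 1.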